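The source may report more compounds than this note shows. Statements on the series, on what has been measured and on what is new or still open speak of the compounds shown alone.

In an ADME assay on Huh-7 cells (Homo sapiens) for cytotoxicity, read by thymidine incorporation (a lower number here means that less compound is tolerated, a higher number that more compound is tolerated), compound 1 `CCc1cn([C@H]2C[C@H](N=[N+]=[N-])[C@@H](CO)O2)c(=O)[nH]c1=O` gives > 100 ug/mL, which is a limit and not a number. Compound 2 `CCc1cn([C@H]2C[C@H](I)[C@@H](CO)O2)c(=O)[nH]c1=O` gives > 100 ug/mL, also a limit. Compound 3 `CCc1cn([C@H]2C[C@H](F)[C@@H](CO)O2)c(=O)[nH]c1=O` gives > 100 ug/mL, again a limit. Among the measured compounds shown here, the series so far therefore offers no exact value: the limit of > 100 ug/mL in this assay, at which 3 of the 3 values shown sit.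

Compound 4 `[N-]=[N+]=N[C@H]1C[C@H](n2cc(F)c(=O)[nH]c2=O)O[C@@H]1CO` differs from compound 1 elsewhere on the structure: fluoro in place of ethyl on an aromatic carbon. The change is fluoro in place of ethyl on an aromatic carbon, and the azido group stays.

The measured steps bear on this only indirectly. a step that the two limits leave unreadable from compound 1 to compound 2, a step that the two limits leave unreadable from compound 1 to compound 3 and a step that the two limits leave unreadable from compound 2 to compound 3 all change the group on a saturated ring carbon, and none changes the ethyl. With no readable size to carry over, no shift beyond the scatter is expected in this assay, although a fall cannot be excluded. The expected size is a number no higher from compound 1 to compound 4 (the limit leaves the size open), an estimate only. For compound 4 the estimated value is 100 ug/mL, with an expected range from 30 ug/mL to 300 ug/mL.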

Compound 4, half-maximal cytotoxic concentration: > 100 ug/mL
Compound 4: no number, only a limit; the forecaster's own chance of this, stated with the estimate: 65%; the middle value sits exactly at the limit.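

Compound 4, like compound 1, gives only a limit, so the step between them cannot be read. The compounds shown leave open where the half-maximal cytotoxic concentration of any of them lies in this assay, and whether fluoro in place of ethyl shifts it.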